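The source may report more compounds than this note shows. Statements on the series, on what has been measured and on what is new or still open speak of the compounds shown alone.

Compound 3 `COc1cccc(N2CCNC(=O)N2)n1` has the highest number among the three compounds measured in a functional assay on cells for inhibition of Polyunsaturated fatty acid 5-lipoxygenase (Homo sapiens); a higher number here means a weaker inhibitor, a lower number a stronger inhibitor: compound 3 gives 3500 nM. Compound 1 `Cc1cccc(N2CC(C)NC(=O)N2)n1` gives 1700 nM, and compound 2 `CC1CN(c2cccc(Cl)n2)NC(=O)N1` gives 1600 nM, so both stand beyond the scatter below compound 3.

Compound 4 `COc1cccc(N2CC(C)NC(=O)N2)n1` keeps the methoxy-bearing pyridine of compound 3 and changes only the saturated ring: methyl in place of hydrogen on a saturated ring carbon. Within the data shown here, that methyl is already present in compound 1 and compound 2, but those two also carry a different group on the aromatic ring, so no single measured step isolates the effect of the methyl. Among the measured compounds shown here, the only step between compounds differing in one place, a 1.1-fold lower number from compound 1 to compound 2 (0.03 log units; within the scatter), concerns the aromatic substituent and lies within the scatter; it bears only indirectly, by showing that the two methyl-bearing compounds sit close together.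

The values of compound 1 and compound 2 lie somewhat below compound 3, which hints that the methyl-bearing ring is associated with a lower number, though the differing aromatic group could account for that. A small step downward, not beyond the scatter, is therefore expected: a 1.4-fold lower number from compound 3 to compound 4 (0.15 log units; within the scatter). For compound 4 the estimate in this assay is 2500 nM, with a range from 1200 nM to 5200 nM.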

Compound 4, half-maximal inhibitory concentration: 7100 nM
Compound 4: middle estimate off by 2.8-fold (0.45 log units), on the low side, and the stated range ends below it.
By their numbers in this assay, from the lowest: compounds 2 and 1 (each within the scatter of the next); then compound 3; then compound 4.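

In this assay, among these compounds, the methyl in place of hydrogen on the saturated ring carbon, with methoxy kept on the aromatic carbon, gives the first measured step that isolates this change (a 2.0-fold higher number from compound 3 to compound 4 (0.31 log units; beyond the scatter)), and it goes towards a weaker inhibitor rather than a stronger one. With that methyl present, the aromatic group also counts: methoxy in place of chloro gives one step up (a 4.4-fold higher number from compound 2 to compound 4 (0.65 log units; beyond the scatter)), and methoxy in place of methyl gives another (a 4.2-fold higher number from compound 1 to compound 4 (0.62 log units; beyond the scatter)), so methoxy now stands apart from two groups that could not be told apart in this assay. Nothing at hand explains either rise in the number.

On these data alone, whether the same methyl also raises the number when chloro or methyl sits on the aromatic carbon stays open, since the methoxy pair is the only one here that isolates it. Also open, as far as these compounds go, is how a larger or different group on that saturated ring carbon, such as an ethyl or an amine, would read, and how a fluoro or an amine would compare with methoxy on the aromatic carbon.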